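The source may hold more compounds than are shown below. What is called first, only, known or untested is meant among the compounds shown, and "the series" means these compounds.

For the measured compounds named here, compound 1 `COc1cc(-c2nc3cc(/C=C4\SC(=O)N(CC(=O)N5CCCCC5)C4=O)ccc3[nH]2)cc(OC)c1OC` is the only compound here with a number: in a functional assay on MDA-MB-231 cells (Homo sapiens) for inhibition, read by MTT assay, with a stated time of 48 h (a higher number here means a weaker inhibitor, a lower number a stronger inhibitor), compound 1 gives 34900 nM. Compound 2 `COc1cc(OC)c(-c2nc3cc(/C=C4\SC(=O)N(CC(=O)N5CCCCC5)C4=O)ccc3[nH]2)cc1OC` is reported only as a limit, (the limit of > 50000 nM in this assay, at which 1 of the 2 values shown sits), so in this assay compound 2 gives > 50000 nM. The step of an at least 1.4-fold higher number from compound 1 to compound 2 (0.15 log units; that floor lies within the scatter) concerns another position. Compound 3 `COc1cc(CN2C(=O)S/C(=C\c3ccc4[nH]c(-c5cc(OC)c(OC)c(OC)c5)nc4c3)C2=O)cc(OC)c1OC` differs from compound 1 by 3,4,5-trimethoxyphenyl in place of (piperidin-1-yl)carbonyl on a saturated chain carbon bound to an amide-type nitrogen in a ring. Going by the values given here, no measured step touches this position, so no shift beyond the scatter is expected. The expected step of a 1.2-fold lower number from compound 1 to compound 3 (0.07 log units; within the scatter) rests only on compound 1 and its value 34900 nM. Compound 3 is therefore estimated at 30000 nM in this assay, within 10000 nM to 90000 nM.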

Compound 3, half-maximal inhibitory concentration: 270 nM
Compound 3: middle estimate off by 110-fold (2.05 log units), on the high side; measured number below the stated range.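

In this assay, putting 3,4,5-trimethoxyphenyl in place of (piperidin-1-yl)carbonyl gives a 130-fold lower number from compound 1 to compound 3 (2.11 log units; beyond the scatter). For the compounds shown here, this position on the saturated chain carbon, which no earlier step touched, therefore has a strong hold on the reading, far stronger than anything the earlier pair could show. The data shown offer no explanation for the size of this step.

Only one replacement is shown here, so it stays open whether the aromatic ring or its three methoxy groups matter more. A plain phenyl ring or a carboxylic acid at this position would help separate these possibilities.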